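Chain Extension on a Urea Tricarboxylic Acid Scaffold

The source may hold more compounds than are shown below. What is called first, only, known or untested is meant among the compounds shown, and "the series" means these compounds.

Compound 1, `CCCCCCCCCCCCCCCCNC(=O)NC(CCC(=O)O)(CCC(=O)O)CCC(=O)O`, was examined in an ADME assay on cells (Epithelial cell, Homo sapiens) for cytotoxicity, read by MTT assay (a lower number here means that less compound is needed, a higher number that more compound is needed for the effect), where compound 1 gives 350000 nM, the highest of the two numbers recorded. Its closest neighbour is compound 2, `CCCCCCCCCCCCCCCCCCCCCC(=O)NC(CCC(=O)O)(CCC(=O)O)CCC(=O)O`, for which compound 2 gives 250000 nM; the two values lie within the scatter of each other. Compound 3, `CCCCCCCCCCCCCCCCCCNC(=O)NC(CCC(=O)O)(CCC(=O)O)CCC(=O)O`, differs from compound 1 by ethyl in place of hydrogen on a saturated chain carbon, ten or more bonds along the chain from an amide-type nitrogen. For the measured compounds named here, with no comparable step recorded, the step from compound 1 to compound 3 is expected to stay within the scatter, a 1.2-fold lower number from compound 1 to compound 3 (0.07 log units; within the scatter). Compound 3 is therefore estimated at 300000 nM, within 150000 nM to 600000 nM.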

Compound 3, half-maximal effective concentration: 280000 nM
Beside the measured number, compound 3's estimate is 1.1-fold (0.03 log units) above it, within the range that was stated.
By their numbers in this assay, from the lowest: compounds 2, 3 and 1 (each within the scatter of the next).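

Ethyl in place of hydrogen on a saturated chain carbon gives a 1.3-fold lower number from compound 1 to compound 3 (0.10 log units; within the scatter) in this assay and so leaves the reading unchanged within the scatter. For the compounds shown here, this is the first recorded step at this position, and it shows that this addition of ethyl does not separate the two compounds. No evidence bearing on this result is available.

The compounds shown leave open whether a much shorter chain, or an amine in place of the ethyl, would move the number beyond the scatter.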